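Compound 2 and the step to a dichlorophenyl

A few compounds are considered here, and "the series" means these few. Any claim that something is new, unique, unknown or untested is made for them only; others in the source may bear on it.

Compound 1 `COc1cc(/C=C/C(=O)C2=C(/C=C/c3ccc(O)c(OC)c3)NC(=S)NC2c2ccccc2)ccc1O` gives 100000 nM
Compound 2 `COc1cc(/C=C/C(=O)C2=C(/C=C/c3ccc(O)c(OC)c3)NC(=S)NC2c2ccc(N(C)C)cc2)ccc1O` gives 25000 nM
Compound 3 `COc1cc(/C=C/C(=O)C2=C(/C=C/c3ccc(O)c(OC)c3)NC(=S)NC2c2c(Cl)cccc2Cl)ccc1O` is not yet measured

In a functional assay on QG-56 cells (Homo sapiens) for cytotoxicity, read by MTT assay, with a stated time of 48 h (a lower number here means a stronger inhibitor, a higher number a weaker inhibitor), compound 2 holds the lower of the two numbers, at 25000 nM as its value. The change to compound 3 is 2,6-dichlorophenyl in place of 4-(dimethylamino)phenyl on a saturated ring carbon and it sits on a saturated ring carbon. Going by the values given here, one measured step bears on this, the modest 4.0-fold lower number from compound 1 to compound 2 (0.60 log units; beyond the scatter) when dimethylamino replaced hydrogen. Among the compounds with values here, compound 3 no longer carries dimethylamino, and no measured compound carries chlorine, so the expectation is loose. In this assay the expected shift is a 2.0-fold higher number from compound 2 to compound 3 (0.30 log units; within the scatter) and so a small rise. For compound 3 the estimate is 50000 nM (range 15000 nM to 130000 nM).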

Compound 3, half-maximal inhibitory concentration: 100000 nM
Estimate against measurement, compound 3: 2.0-fold (0.30 log units) below, within the range that was stated.
By their numbers in this assay, from the lowest: compound 2; then compounds 1 and 3 (each within the scatter of the next).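

In this assay there is a 4.0-fold higher number from compound 2 to compound 3 (0.60 log units; beyond the scatter) when 2,6-dichlorophenyl replaces 4-(dimethylamino)phenyl on this saturated ring carbon, so the lower number of compound 2 is not kept with this replacement. Placing 2,6-dichlorophenyl where phenyl stood gives no change at the digits printed from compound 1 to compound 3 (within the scatter) and so leaves the number where it was. No measured evidence accounts for these results.

The compounds shown leave open whether a methoxy group or a plain amino group on the phenyl ring would match or improve on dimethylamino. They also leave open whether a single chlorine would behave like 2,6-dichlorophenyl.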